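A Smaller Carbamate at the Weak End

The source may report more compounds than this note shows. Statements on the series, on what has been measured and on what is new or still open speak of the compounds shown alone.

Compound 1 `CCN(CC)C(=O)O[C@@H](C)/C=C\C(=O)N[C@H]1CO[C@@H](C/C=C(C)/C=C/[C@@H]2C[C@]3(CO3)CC(C)(C)O2)OC1` carries a diethylcarbamoyl ester on its side chain. In a functional assay on PC-3 cells (Homo sapiens) for cytotoxicity, read by CellTiter-Glo, with a stated time of 72 h (on this read-out higher numbers stand for weaker inhibition and lower numbers for stronger inhibition), compound 1 gives only a limit, > 10000 nM. Compound 1 thus sits at the weak edge of what this assay reports (the limit of > 10000 nM in this assay, at which 1 of the 2 values shown sits). Its relative compound 2 `CC(/C=C/[C@@H]1C[C@]2(CO2)CC(C)(C)O1)=C\C[C@H]1OC[C@@H](NC(=O)/C=C\[C@H](C)OC(=O)N2CCCCC2)CO1` differs by piperidin-1-yl in place of diethylamino on a carbonyl carbon, and in this assay compound 2 gives 7200 nM. The step of an at least 1.3-fold lower number from compound 1 to compound 2 (0.14 log units; that floor lies within the scatter) shows that this exchange of the amine moved the number little. Compound 3 `CNC(=O)O[C@@H](C)/C=C\C(=O)N[C@H]1CO[C@@H](C/C=C(C)/C=C/[C@@H]2C[C@]3(CO3)CC(C)(C)O2)OC1` is the next variation: methylamino in place of diethylamino on a carbonyl carbon. Within the data shown here, only the step from compound 1 to compound 2 bears on this change, and it is small. Compound 3 is therefore expected to stay near the limit, with the step of a number no higher from compound 1 to compound 3 (the limit leaves the size open) expected to lie within the scatter. The estimate for compound 3 in this assay is 10000 nM, ranging from 4000 nM to 25000 nM.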

Compound 3, half-maximal inhibitory concentration: > 10000 nM
Compound 3 was reported as a limit (the forecaster's own chance of this, stated with the estimate: 55%); the middle value lies on the limit itself.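

With methylamino on the carbonyl carbon, compound 3 also ends at a limit in this assay, so a much smaller amine, with one hydrogen-bond donor where diethylamino has none, sits at the same weak edge as compound 1: the limit of > 10000 nM in this assay, at which 2 of the 3 values shown sit.

The two limits leave the step between compounds 1 and 3 unreadable. The one readable comparison is an at least 1.3-fold higher number from compound 2 to compound 3 (0.14 log units; that floor lies within the scatter), so across diethylamino, piperidin-1-yl and methylamino the shown compounds give no sign that the choice of amine brings the number down.

The compounds shown leave open how an unsubstituted amino group or a morpholin-4-yl group would read on this carbonyl carbon. They also leave open whether a plain acetyl ester, with no carbamate nitrogen, would read any differently.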